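The source may report more compounds than this note shows. Statements on the series, on what has been measured and on what is new or still open speak of the compounds shown alone.

Measured in a functional assay on the whole organism with Mus musculus as the target; on this read-out higher numbers stand for an effect only at larger amounts of compound and lower numbers for an effect already at smaller amounts:
- compound 1 `C[C@@H](NCc1ccc(OCCc2ccccc2)cc1)C(N)=O` gives 24.9 mg/kg
- compound 2 `C[C@@H](NCc1ccc(OCc2ccccc2Cl)cc1)C(N)=O` gives 17.4 mg/kg
- compound 3 `C[C@@H](NCc1ccc(OCc2ccco2)cc1)C(N)=O` gives 116 mg/kg

Compound 3 carries the highest number of the three, and its gaps to both others lie beyond the scatter. The next compound is compound 4 `C[C@@H](NCc1ccc(OCC2CC2)cc1)C(N)=O`, with the change cyclopropyl in place of furan-2-yl on a saturated chain carbon bound to an oxygen on an aromatic ring.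

Two measured steps bring in furan-2-yl at this place: a 4.7-fold higher number from compound 1 to compound 3 (0.67 log units; beyond the scatter) and a 6.7-fold higher number from compound 2 to compound 3 (0.82 log units; beyond the scatter). Both are modest and go the same way. The third step, a 1.4-fold lower number from compound 1 to compound 2 (0.16 log units; within the scatter), shows no separation between the other two compounds. Among the compounds with values here, no measured compound has a non-aromatic ring at this place, so the data do not fix the size of the coming step. Removing furan-2-yl may give back part of those two steps, so a small fall in the number is expected in this assay, though perhaps none beyond the scatter. The expected move is a 1.7-fold lower number from compound 3 to compound 4 (0.22 log units; within the scatter). For compound 4 the estimated value is 70 mg/kg, with an expected range from 28 mg/kg to 170 mg/kg.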

Compound 4, dose for half-maximal effect: 124 mg/kg
Estimate against measurement, compound 4: 1.8-fold (0.25 log units) below; the range from low to high includes it.
By their numbers in this assay, from the lowest: compounds 2 and 1 (each within the scatter of the next); then compounds 3 and 4 (each within the scatter of the next).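

In this assay, cyclopropyl in place of furan-2-yl gives a 1.1-fold higher number from compound 3 to compound 4 (0.03 log units; within the scatter), so these two groups cannot be told apart at this place on a saturated chain carbon bound to an oxygen on an aromatic ring, even though one is a five-membered aromatic ring with a hetero atom and the other a three-membered non-aromatic ring of carbon only. The separation from the two compounds carrying benzyl and 2-chlorophenyl also holds for the non-aromatic ring, with a 7.1-fold higher number from compound 2 to compound 4 (0.85 log units; beyond the scatter) and a 5.0-fold higher number from compound 1 to compound 4 (0.70 log units; beyond the scatter), so an aromatic ring at this place does not by itself sort the four compounds into their two pairs. Nothing at hand gives a measured basis for explaining this split.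

Going by these compounds, whether an open-chain group such as propyl, a cyclohexyl ring or an amine at this place would fall with compound 1 and compound 2 or with compound 3 and compound 4 remains open. Also open, on these data alone, is whether the chlorine of 2-chlorophenyl contributes anything, since the gap between compound 1 and compound 2 lies within the scatter and the two also differ in the chain.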